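Anilino variation on the shared core: toward the dimethoxyphenyl analogue

This account rests on a few compounds, and the source may have more. Where it says the series, first, only, none or still open, it means among the compounds named here.

Three anilino variants of the shared core have numbers in a functional assay on BT-549 cells (Homo sapiens) for cytotoxicity, read by sulforhodamine B assay, with a stated time of 72 h; on this read-out lower numbers stand for stronger inhibition and higher numbers for weaker inhibition. Compound 1 `CCS(=O)(=O)Nc1cc(-c2ccc3ncnc(Nc4cccc(F)c4)c3c2)cnc1OC` gives 2760 nM, compound 2 `CCS(=O)(=O)Nc1cc(-c2ccc3ncnc(Nc4ccc(F)cc4)c3c2)cnc1OC` gives 3120 nM, and compound 3 `CCS(=O)(=O)Nc1cc(-c2ccc3ncnc(Nc4ccc(OC(F)(F)F)cc4)c3c2)cnc1OC` gives 8240 nM, the highest of the three; the step of a 2.6-fold higher number from compound 2 to compound 3 (0.42 log units; beyond the scatter) and the step of a 3.0-fold higher number from compound 1 to compound 3 (0.48 log units; beyond the scatter) both exceed the scatter, while a 1.1-fold higher number from compound 1 to compound 2 (0.05 log units; within the scatter) does not. Compound 4 `CCS(=O)(=O)Nc1cc(-c2ccc3ncnc(Nc4ccc(OC)c(OC)c4)c3c2)cnc1OC` differs from compound 3 by 3,4-dimethoxyphenyl in place of 4-(trifluoromethoxy)phenyl on a nitrogen on an aromatic ring. Going by the values given here, no measured step replaces the whole ring substituent pattern by two methoxy groups, so the two modest steps onto compound 3 give only loose guidance; a step of either direction within or just beyond the scatter is expected, a 1.6-fold lower number from compound 3 to compound 4 (0.22 log units; within the scatter). Compound 4 is therefore estimated at 5000 nM in this assay, with a range from 1500 nM to 16000 nM.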

Compound 4, half-maximal inhibitory concentration: 2590 nM
Compound 4: middle estimate off by 1.9-fold (0.29 log units), on the high side; measured number inside the range.
By their numbers in this assay, from the lowest: compounds 4, 1 and 2 (each within the scatter of the next); then compound 3.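

At this position, on a nitrogen on an aromatic ring, the step to 3,4-dimethoxyphenyl in this assay is beyond the scatter, a 3.2-fold lower number from compound 3 to compound 4 (0.50 log units; beyond the scatter), so compound 3 stands apart from compound 4. Compound 4 stays within the scatter of both fluorophenyl compounds, a 1.2-fold lower number from compound 2 to compound 4 (0.08 log units; within the scatter), and a 1.1-fold lower number from compound 1 to compound 4 (0.03 log units; within the scatter), so this larger ring pattern does not separate it from them. No evidence on these groups accompanies the numbers.

Still open, as far as these compounds go, is whether a single methoxy group would match the two together. Also open, from the compounds shown here alone, is how an amine or a carboxylic acid on this ring would read.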